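The source may report more compounds than this note shows. Statements on the series, on what has been measured and on what is new or still open speak of the compounds shown alone.

Measured so far in a functional assay on the whole organism for antagonist activity, with Mus musculus as the target; a higher number here means that more compound is needed for the effect, a lower number that less compound is needed:
Compound 1 `O=C1NCCN1CC#CCn1ccnc1`: > 100 mg/kg (a limit)
Compound 2 `CN1CCN(CC#CCn2ccnc2)C1=O`: > 100 mg/kg (a limit)
Compound 3 `Cc1cncn1CC#CCN1CCN(C)C1=O`: > 100 mg/kg (a limit)

Compound 2 has no number in this assay, only the limit > 100 mg/kg. The two other measured compounds offer no number to compare it with, and the whole record is the limit of > 100 mg/kg in this assay, at which 3 of the 3 values shown sit.

The next compound is compound 4 `CC(C#CCn1ccnc1)N1CCN(C)C1=O`, which carries one change relative to compound 2: methyl in place of hydrogen on a saturated chain carbon bound to an amide-type nitrogen in a ring and a triple-bonded carbon. The new methyl therefore stands on a saturated chain carbon bound to an amide-type nitrogen in a ring and a triple-bonded carbon.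

Two measured steps also put a methyl in place of a hydrogen, though at other places. One is a step that the two limits leave unreadable from compound 1 to compound 2, on an amide-type nitrogen in a ring. The other is a step that the two limits leave unreadable from compound 2 to compound 3, on an aromatic carbon. Going by the values given here, neither gives a size or a direction, and no measured step touches the chain carbon.

No readable shift can therefore be predicted, and the most likely outcome is another limit. Only a tentative expected change can be given, a step that the limit leaves unreadable from compound 2 to compound 4, with no firm direction. For compound 4 the estimate is 120 mg/kg, with an expected range from 40 mg/kg to 300 mg/kg.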

Compound 4, dose for half-maximal effect: > 100 mg/kg
Compound 4 gave a limit, no number (the forecaster's own chance of this, stated with the estimate: 70%); the middle value does not contradict the limit.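

In this assay compound 4 gives > 100 mg/kg, which is a limit and not a number. Compound 2 also has only a limit, so no step can be read between compound 2 and compound 4. The compounds shown leave open whether a methyl at any of these places changes the dose needed, and whether any of these compounds would give a number at all: the limit of > 100 mg/kg in this assay, at which 4 of the 4 values shown sit.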